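The source may hold more compounds than are shown below. What is called first, only, known or untested is meant among the compounds shown, and "the series" means these compounds.

Working notes on the series. Compound 1 `COc1cc(OC)c2sc(-c3ccc(N/C=C\C(=O)c4ccc(OC)c(O)c4)c(C)c3)nc2c1` serves as the starting point; in a functional assay on MDA-MB-231 cells (Homo sapiens) for antiproliferative activity, read by sulforhodamine B assay, with a stated time of 48 h (on this read-out lower numbers stand for stronger inhibition and higher numbers for weaker inhibition), compound 1 gives 3100 nM. Compound 3 `COc1cc(OC)c2sc(-c3ccc(N/C=C\C(=O)c4ccc(OC)c(O)c4)cc3)nc2c1` differs from compound 1 by hydrogen in place of methyl on an aromatic carbon, and in this assay compound 3 gives 7610 nM, so that a 2.5-fold higher number from compound 1 to compound 3 (0.39 log units; beyond the scatter). Compound 2 `COc1ccc2nc(-c3ccc(N/C=C\C(=O)c4ccc(OC)c(O)c4)c(C)c3)sc2c1` has another core; the difference between the core of compound 2 and the core of compound 1 is not broken down here. In this assay compound 2 gives 14000 nM, which lies beyond the scatter from compound 1 and within the scatter of compound 3. Compound 4 `COc1ccc2nc(-c3ccc(N/C=C\C(=O)c4ccc(OC)c(O)c4)cc3)sc2c1` has not been measured; it differs from compound 2 by hydrogen in place of methyl on an aromatic carbon, the same change as from compound 1 to compound 3, at a place described in the same words. Going by the values given here, only one measured instance of this change exists in the set, so the expectation rests on a single step. For compound 4 the expected step is a 2.5-fold higher number from compound 2 to compound 4 (0.40 log units; beyond the scatter), set beside the measured 2.5-fold higher number from compound 1 to compound 3 (0.39 log units; beyond the scatter) for the same change on the other core, with wide uncertainty since the cores differ. The estimate for compound 4 is 35000 nM, expected to fall between 14000 nM and 90000 nM.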

Compound 4, half-maximal inhibitory concentration: 18900 nM
For compound 4 the middle estimate is 1.9-fold (0.27 log units) above the measured one; measured number inside the range.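

In this assay hydrogen in place of methyl on an aromatic carbon gives a 1.4-fold higher number from compound 2 to compound 4 (0.13 log units; within the scatter). Set beside the earlier step, the two cores do not separate for this change: the same change on two cores in this assay, a 2.5-fold higher number (0.39 log units; beyond the scatter) from compound 1 to compound 3 and a 1.4-fold higher number (0.13 log units; within the scatter) from compound 2 to compound 4, 1.8-fold (0.26 log units) apart, within the scatter of two such steps. This fits the change carrying over from the core of compound 1 to the core of compound 2, but it does not show that the step has the same size on both cores, since only two instances exist and the step on the core of compound 2 is itself within the scatter, nor does it show that the methyl matters at all on that core.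

The compounds shown leave open whether another group on this aromatic carbon, such as an ethyl group, a chlorine atom or an amine, would move the number on either core. They also leave open whether the change behaves in the same way on any core other than these two.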